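A Second Methoxy Group on the Pendant Phenyl

The source may hold more compounds than are shown below. What is called first, only, known or untested is meant among the compounds shown, and "the series" means these compounds.

Three compounds have been measured:
compound 1 `Cc1cc(O)c(C(C)C)cc1-c1cc(-c2ccccc2)c(C#N)c(=O)[nH]1` gives 41% in a functional assay for inhibition, tested at 100 ug/mL; on this read-out higher numbers stand for a stronger effect at the one concentration tested and lower numbers for a weaker effect;
compound 2 `COc1ccc(-c2cc(-c3cc(C(C)C)c(O)cc3C)[nH]c(=O)c2C#N)cc1` gives 54%;
compound 3 `Cc1cc(O)c(C(C)C)cc1-c1cc(-c2ccco2)c(C#N)c(=O)[nH]1` gives 70%.

Compound 1 is the lowest of the three numbers. Compound 2 stands a number 13 percentage points higher from compound 1 to compound 2 (beyond the scatter), and compound 3 stands a number 29 percentage points higher from compound 1 to compound 3 (beyond the scatter), so both steps away from compound 1 point upward and both are beyond the scatter. Compound 3 also stands a number 16 percentage points higher from compound 2 to compound 3 (beyond the scatter).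

Compound 4 `COc1ccc(-c2cc(-c3cc(C(C)C)c(O)cc3C)[nH]c(=O)c2C#N)cc1OC` is not yet measured. It differs from compound 1 in one place: 3,4-dimethoxyphenyl in place of phenyl on an aromatic carbon. The measured step that bears most directly on this change is a number 13 percentage points higher from compound 1 to compound 2 (beyond the scatter), where one methoxy group entered on the same pendant ring and gave a modest rise. Going by the values given here, compound 4 carries two such groups, and no measured pair shows what a second methoxy adds, so the expectation rests on the single-methoxy step alone. A modest rise over compound 1 is therefore expected, of about the size already seen with compound 2, with the possibility of a little more or of no further gain beyond the first methoxy. For compound 4 the expected step is a number 16 percentage points higher from compound 1 to compound 4 (beyond the scatter) in this assay. The estimate for compound 4 is 57%, with a range from 40% to 74%.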

Compound 4, a percentage reported as inhibition, at one concentration (the size of the read-out at that concentration, not a potency): 61%
Compound 4: the middle estimate sits 4 percentage points below what was measured; low and high end bracket the measured number.
By their numbers in this assay, from the lowest: compound 1; then compounds 2, 4 and 3 (each within the scatter of the next, the first and the last beyond it).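

In this assay, 3,4-dimethoxyphenyl in place of phenyl on the carbon opposite the ring nitrogen gives a number 20 percentage points higher from compound 1 to compound 4 (beyond the scatter) and shows that this position still tolerates a larger group with two methoxy groups, while the rise over the unsubstituted phenyl of compound 1 remains clear. The first direct view of a second methoxy group is a number 7 percentage points higher from compound 2 to compound 4 (within the scatter) and this places any contribution from that group inside the usual scatter, so compound 4 cannot be told apart from compound 2. Set against the furan-2-yl group, the change gives a number 9 percentage points lower from compound 3 to compound 4 (within the scatter) and compound 4 cannot be told apart from compound 3 either, while nothing measured here accounts for any of these numbers.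

The compounds shown leave open whether an amine or a carboxylic acid on the same phenyl ring would behave as methoxy does, and whether a thiophene ring would match the furan-2-yl group. Each number also gives only the size of the effect at one concentration, so the potency of these compounds remains unknown.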